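Butyl to cyclohexylmethyl on the shared core

The compounds below may be only part of what the source reports. "The series", "measured", "known", "first", "only" and "open" are said of these compounds alone.

In a functional assay (trachea) with Cavia porcellus as the target (on this read-out higher numbers stand for weaker inhibition and lower numbers for stronger inhibition), compound 1 `Oc1nnc(-c2cccnc2)c2ccccc12` gives 10200 nM and compound 2 `CCCCn1nc(-c2cccnc2)c2ccccc2c1=O` gives 2290 nM as the lower of the two numbers, with a gap beyond the usual scatter. Compound 3 `O=c1c2ccccc2c(-c2cccnc2)nn1CC1CCCCC1` has not yet been measured. Its difference from compound 2 is cyclohexyl in place of propyl on a saturated chain carbon bound to an aromatic nitrogen and reads in words as cyclohexyl in place of propyl on a saturated chain carbon bound to an aromatic nitrogen, or, cut one bond further out, as butyl to cyclohexylmethyl. Among the compounds with values here, no measured step covers a change of this kind, so the expectation in this assay is a loose one. The expected step of a 1.3-fold lower number from compound 2 to compound 3 (0.13 log units; within the scatter) is small, points to a slightly lower number and may not clear the scatter. For compound 3 the estimated value is 1700 nM with an expected range from 500 nM to 5500 nM in this read-out.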

Compound 3, half-maximal inhibitory concentration: 209 nM
Beside the measured number, compound 3's estimate is 8.1-fold (0.91 log units) above it, outside the stated range (below it).
By their numbers in this assay, from the lowest: compound 3; then compound 2; then compound 1.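

In this assay, within the data shown here, the group on the saturated chain carbon bound to an aromatic nitrogen proves able to move the read-out strongly: butyl to cyclohexylmethyl gives an 11-fold lower number from compound 2 to compound 3 (1.04 log units; beyond the scatter) and is the first one-place change that can be read. Cyclohexyl in place of propyl brings a six-membered non-aromatic ring of carbon only and no hydrogen-bond donors or acceptors, so a change of carbon alone at this position is enough for a large step. Nothing at hand accounts for the size of this step.

Open, from the compounds shown here alone, is whether the ring or simply the larger number of carbons goes with the lower number, a question that a longer chain such as heptyl or a benzyl group could address. Also open, going by these compounds, is how an amine or a carboxylic acid on the cyclohexyl ring would read.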